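Carbonyl substituent variation: expectation for compound 3

This account rests on a few compounds, and the source may have more. Where it says the series, first, only, none or still open, it means among the compounds named here.

Two compounds of the series carry a measured maximal response. Compound 1 `Cc1nc(S(C)(=O)=O)ccc1Oc1ncnc(OC2CCN(C(=O)OC3COC3)CC2)c1F` gives in a functional assay on isolated protein for inhibition of Glucose-dependent insulinotropic receptor (Rattus norvegicus), read by HTRF and cAMP accumulation (on this read-out higher numbers stand for larger maximal responses and lower numbers for smaller maximal responses), 66%. Within the data shown here, compound 2 `CCC(F)(F)C(=O)N1CCC(Oc2ncnc(Oc3ccc(S(C)(=O)=O)nc3C)c2F)CC1` gives in this assay 90%, the higher of the two numbers; its nearest neighbour is compound 1, and the only measured step, a number 24 percentage points higher from compound 1 to compound 2 (beyond the scatter), came from 1,1-difluoropropyl in place of (oxetan-3-yl)oxy on a carbonyl carbon.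

Compound 3 `Cc1nc(S(C)(=O)=O)ccc1Oc1ncnc(OC2CCN(C(=O)C3(F)CCC3)CC2)c1F` is not yet measured. It differs from compound 2 at that same carbonyl carbon: a group of 5 heavy atoms (4 carbon, 1 fluorine; one four-membered non-aromatic ring of carbon only) in place of a group of 5 heavy atoms (3 carbon, 2 fluorine; no ring), on a carbonyl carbon. Among the measured compounds shown here, the single measured step bears on this position and shows that a change there can move the number beyond the scatter, but no measured pair exchanges one group of 5 heavy atoms carrying fluorine for another of the same size. Compound 3 is therefore expected to stay close to compound 2, with the step of a number 5 percentage points lower from compound 2 to compound 3 (within the scatter) expected to remain within the scatter. The estimated value for compound 3 in this assay is 85%, with a range from 70% to 100%.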

Compound 3, largest response reached (reported as efficacy), in percent of the reference or control that the assay uses: 91%
Estimate against measurement, compound 3: 6 percentage points below; low and high end bracket the measured number.
By their numbers in this assay, from the lowest: compound 1; then compounds 2 and 3 (each within the scatter of the next).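

In this assay the exchange on the carbonyl carbon gives a number 1 percentage points higher from compound 2 to compound 3 (within the scatter) and so shows that a fluorinated four-membered carbon ring can stand in for 1,1-difluoropropyl, at the same count of heavy atoms, without a shift beyond the scatter. With a number 25 percentage points higher from compound 1 to compound 3 (beyond the scatter) now beside a number 24 percentage points higher from compound 1 to compound 2 (beyond the scatter) as a second step of this kind, a four-membered ring as such does not settle the number, since compound 1 and compound 3 both carry one. No measurement at hand accounts for either step.

The compounds shown leave open whether fluorine matters at this position, which a cyclobutyl group without fluorine or a plain propyl chain on the same carbonyl carbon would tell. They also leave open how far this tolerance extends to larger groups, such as a cyclohexyl ring.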